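A few compounds are considered here, and "the series" means these few. Any claim that something is new, unique, unknown or untested is made for them only; others in the source may bear on it.

Measured compounds:
Compound 1, `COc1ccc(CN2C(=O)CC[C@H]2C(=N)NCc2ccccc2)cc1`: 21%
Compound 2, `COc1ccc(CN2C(=O)CC[C@H]2C(=N)NCc2ccc(O)cc2)cc1`: 20.5%
Compound 3, `Cc1ccc(CN2C(=O)CC[C@H]2C(=N)NCc2ccccc2)cc1`: 23.5%

All three were tested in a functional assay on SH-SY5Y cells (Homo sapiens) for cytotoxicity, read by MTT assay, with stated times of 8 h, 30 min and 12 h, tested at 0.5 uM; a higher number here means a stronger effect of the compound at the concentration tested, a lower number a weaker effect. Among the compounds with values here, compound 1 gives 21%, compound 2 gives 20.5% and compound 3 gives 23.5%; no pair of these values lies outside the usual scatter of repeated measurements, so no order among them can be read from the data.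

The change from compound 1 to compound 2 is hydroxy in place of hydrogen on an aromatic carbon. The step it produced is a number 0.5 percentage points lower from compound 1 to compound 2 (within the scatter). The core of compound 3 differs from the core of compound 1 by methyl in place of methoxy on an aromatic carbon, with the step of a number 2.5 percentage points higher from compound 1 to compound 3 (within the scatter).

Compound 4, `Cc1ccc(CN2C(=O)CC[C@H]2C(=N)NCc2ccc(O)cc2)cc1`, has not been measured in this assay. It differs from compound 3 by hydroxy in place of hydrogen on an aromatic carbon, the same change that was made from compound 1 to compound 2, now made on the core of compound 3 and occurring twice among the compounds shown.

The step from compound 3 to compound 4 in this assay is expected to be a number 0.5 percentage points lower from compound 3 to compound 4 (within the scatter), close to the earlier one, because the same change gave a number 0.5 percentage points lower from compound 1 to compound 2 (within the scatter) and because compound 3 stands at 23.5%. Compound 4 is therefore estimated at 23%, with a range of 15% to 31%.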

Compound 4, a percentage reported as activity, at one concentration (the size of the read-out at that concentration, not a potency): 21.9%
Compound 4: the middle estimate sits 1.1 percentage points above what was measured; low and high end bracket the measured number.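

In this assay hydroxy in place of hydrogen on the aromatic carbon, carried to the core of compound 3, gives a number 1.6 percentage points lower from compound 3 to compound 4 (within the scatter) and agrees with the step on the core of compound 1: the same change on two cores in this assay, a number 0.5 percentage points lower (within the scatter) from compound 1 to compound 2 and a number 1.6 percentage points lower (within the scatter) from compound 3 to compound 4, 1.1 percentage points apart, within the scatter of two such steps. Methyl in place of methoxy, read on the hydroxylated core, gives a number 1.4 percentage points higher from compound 2 to compound 4 (within the scatter) and likewise agrees with the earlier step: the same change on two cores in this assay, a number 2.5 percentage points higher (within the scatter) from compound 1 to compound 3 and a number 1.4 percentage points higher (within the scatter) from compound 2 to compound 4, 1.1 percentage points apart, within the scatter of two such steps. Within the data shown here, all of these steps lie within the scatter, so the series shows only that neither change produced a readable effect on either core at this one concentration, and it does not show that either change carries a real effect of any size from one core to another.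

Still open, as far as these compounds go, is whether an amine or a carboxylic acid in place of the hydroxy, or a longer chain in place of the methyl, would move the read-out beyond the scatter. The compounds shown also leave open how these changes behave at other concentrations.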